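Aryl swap on the ring nitrogen: expectation for compound 4

This account rests on a few compounds, and the source may have more. Where it says the series, first, only, none or still open, it means among the compounds named here.

Compound 1 `COc1cccc(N2CCN(C(=O)C(C)N3C(=O)CCC3=O)CC2)c1`, compound 2 `CC(C(=O)N1CCN(c2ccccc2)CC1)N1C(=O)CCC1=O` and compound 3 `CC(C(=O)N1CCN(c2ccc(Cl)cc2)CC1)N1C(=O)CCC1=O` share one core and differ only in the aryl group on the amine nitrogen in the ring. In a functional assay on the whole organism (strain Swiss) with Mus musculus as the target, in the maximal electroshock model, with a stated time of 2 h, at a dose of 300 mg/kg by the intraperitoneal route (on this read-out lower numbers stand for a weaker effect and higher numbers for a stronger effect at the one dose given), compound 1 gives 0%, compound 2 gives 0% and compound 3 gives 0%. The steps of no change at the digits printed from compound 1 to compound 2 (within the scatter), no change at the digits printed from compound 1 to compound 3 (within the scatter) and no change at the digits printed from compound 2 to compound 3 (within the scatter) are all flat, so compound 3 stands level with compounds 1 and 2. Compound 4 `CC(C(=O)N1CCN(c2ccccc2F)CC1)N1C(=O)CCC1=O` differs from compound 3 by 2-fluorophenyl in place of 4-chlorophenyl on an amine nitrogen in a ring. All three measured aryl changes at this position left this assay unchanged, and nothing shown points in any direction for this further change. Compound 4 is therefore expected at 0%, range 0% to 10%, the expected step of no change at the digits printed from compound 3 to compound 4 (within the scatter) being none beyond the scatter.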

Compound 4, a percentage reported as activity, at one dose (the size of the read-out at that dose, not a potency): 25%
The estimate for compound 4 lay 25 percentage points below the measured number; the whole stated range lies below it.
By their numbers in this assay, from the lowest: compounds 1, 2 and 3 (each within the scatter of the next); then compound 4.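

In this assay the aryl group on the amine nitrogen in the ring is not silent after all: 2-fluorophenyl gives a number 25 percentage points higher from compound 3 to compound 4 (beyond the scatter), a number 25 percentage points higher from compound 2 to compound 4 (beyond the scatter) and a number 25 percentage points higher from compound 1 to compound 4 (beyond the scatter). Fluoro in place of hydrogen is thus enough to separate compound 4 from compound 2, whereas chloro in place of hydrogen gave no change at the digits printed from compound 2 to compound 3 (within the scatter). Nothing available bears on the reason for this rise.

On these data alone, whether the rise follows the fluoro itself or its place on the phenyl ring remains open. 4-Fluorophenyl and 2-chlorophenyl on the same nitrogen would separate the two.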